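This account rests on a few compounds, and the source may have more. Where it says the series, first, only, none or still open, it means among the compounds named here.

Compound 1 `O=C(O)COc1ccccc1C#Cc1ccccc1Cl` stands at the highest number of the two compounds measured in an assay on CHO cells for displacement of a labelled ligand from prostaglandin D2 receptor 2 (Homo sapiens), read by scintillation counting; a higher number here means a weaker inhibitor, a lower number a stronger inhibitor; in that test compound 1 gives 747 nM. The nearest neighbour is compound 2 `O=C(O)COc1ccc(Cl)cc1C#Cc1ccccc1`, which in this assay gives 108 nM, a lower number beyond the usual scatter. Compound 3 `N#Cc1ccc(OCC(=O)O)c(C#Cc2ccccc2Cl)c1` differs from compound 1 in one change: cyano in place of hydrogen on an aromatic carbon. For the measured compounds named here, no measured pair shows this exact change, so its size is open. The step is expected to be a 3.0-fold lower number from compound 1 to compound 3 (0.48 log units; beyond the scatter), toward a lower number. Compound 3 is estimated to give 250 nM in this assay, somewhere between 80 nM and 700 nM.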

Compound 3, inhibition constant: 24 nM
Compound 3: the middle estimate sits 10-fold (1.02 log units) above what was measured; measured number outside the range, below it.
By their numbers in this assay, from the lowest: compound 3; then compound 2; then compound 1.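

In this assay, putting cyano in place of hydrogen on this aromatic carbon, para to a carboxymethoxy group, gives a 31-fold lower number from compound 1 to compound 3 (1.49 log units; beyond the scatter). This shows that the position is far from indifferent: one change here moves the number by a large step, well beyond the scatter. No measurement shown explains why the step is so large. As far as these compounds go, whether an amine, a methoxy group or a carboxylic acid on the same carbon would give a similar step remains open. So does whether cyano would have the same effect on another carbon of this ring.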